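A few compounds are considered here, and "the series" means these few. Any claim that something is new, unique, unknown or untested is made for them only; others in the source may bear on it.

Of the compounds shown here, three have been measured in an assay on isolated protein for inhibition of leukotriene B4 receptor 1 (Homo sapiens), tested at 10 uM; on this read-out higher numbers stand for more inhibition at the one concentration tested (going by the name of the read-out) and lower numbers for less inhibition. Compound 1 `CC(=O)c1cc(C(C)=O)c(OCCCCC#N)cc1O` gives 8%. Compound 2 `CCc1cc(C(C)=O)c(O)cc1OCCCCC(C)(C)C#N` gives 79%, and compound 3 `CCc1cc(C(C)=O)c(O)cc1OCCCCCCCC(C)(C)C#N` gives 66%. Compound 2 stands highest of the three, with a number 13 percentage points lower from compound 2 to compound 3 (beyond the scatter), and compound 1 lies further below it still, also beyond the scatter.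

Compound 4 `CCc1cc(C(C)=O)c(O)cc1OCCCC(C)(C)C(N)=O` has not yet been measured. Its difference from compound 2 is 1-carbamoyl-1-methylethyl in place of 2-cyano-2-methylpropyl on a saturated chain carbon, three bonds along the chain from an oxygen on an aromatic ring. Within the data shown here, no measured step exchanges a nitrile for a carbamoyl group, so the only step known, the one from compound 2 to compound 3, bears on it loosely at most: it concerns chain length alone and was modest. Among the measured compounds shown here, the hydrogen-bond donor that enters has no counterpart among the measured compounds.

Compound 4 is therefore expected to sit somewhat below compound 2, with a step of about a number 29 percentage points lower from compound 2 to compound 4 (beyond the scatter), carrying wide uncertainty. The estimate for compound 4 in this assay is 50%, with a range from 20% to 78%.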

Compound 4, a percentage reported as inhibition, at one concentration (the size of the read-out at that concentration, not a potency): 92%
The estimate for compound 4 lay 42 percentage points below the measured number; the whole stated range lies below it.
By their numbers in this assay, from the lowest: compound 1; then compound 3; then compound 2; then compound 4.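

In this assay, the step of a number 13 percentage points higher from compound 2 to compound 4 (beyond the scatter) shows that the end of the chain can change in kind and the number still rises, whereas the earlier step among the nitriles changed only the chain length. On a saturated chain carbon, three bonds along the chain from an oxygen on an aromatic ring, 1-carbamoyl-1-methylethyl thus serves better than 2-cyano-2-methylpropyl, and the hydrogen-bond donor it brings costs nothing on this read-out. No evidence on hand accounts for the rise.

The compounds shown leave open whether a carboxylic acid or an amine at the same place would hold this level, and whether the carbamoyl group gives a similar step on the longer chain of compound 3. On these data alone, since the read-out covers one concentration, the potency of compound 4 also remains open.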